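Aryloxy swap at the shared core: compound 3 to compound 4

The compounds below may be only part of what the source reports. "The series", "measured", "known", "first", "only" and "open" are said of these compounds alone.

Compound 1 `Cc1nn(C)c(Oc2cccc(F)c2)c1/C=N\CCCCCCOc1cc2oc(=O)cc(C)c2cc1Cl` in a functional assay on U-87MG ATCC cells for antiproliferative activity against U-87 MG (Homo sapiens), read by MTT assay, with a stated time of 72 h (on this read-out higher numbers stand for weaker inhibition and lower numbers for stronger inhibition), gives only a limit, > 25000 nM (the limit of > 25000 nM in this assay, at which 1 of the 3 values shown sits). Compound 2 `Cc1nn(C)c(Oc2ccccc2Br)c1/C=N\CCCCCCOc1cc2oc(=O)cc(C)c2cc1Cl` gives 21800 nM and compound 3 `Cc1nn(C)c(Oc2ccc(I)cc2)c1/C=N\CCCCCCOc1cc2oc(=O)cc(C)c2cc1Cl` gives 16800 nM; compound 3 holds the lowest of the two numbers, with compound 2 nearest and within the scatter. The changes made so far on this oxygen moved little: an at least 1.1-fold lower number from compound 1 to compound 2 (0.05 log units; that floor lies within the scatter), an at least 1.4-fold lower number from compound 1 to compound 3 (0.17 log units; that floor lies within the scatter), a 1.3-fold lower number from compound 2 to compound 3 (0.11 log units; within the scatter). Compound 4 `Cc1ccccc1Oc1c(/C=N\CCCCCCOc2cc3oc(=O)cc(C)c3cc2Cl)c(C)nn1C` carries 2-methylphenyl in place of 4-iodophenyl on an oxygen on an aromatic ring. Every measured step at this position stays within the scatter, so no step beyond the scatter is expected in this assay. Compound 4 is therefore estimated at 18000 nM, between 8000 nM and 40000 nM. The expected step is a 1.1-fold higher number from compound 3 to compound 4 (0.03 log units; within the scatter).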

Compound 4, half-maximal inhibitory concentration: 9610 nM
Compound 4: middle estimate off by 1.9-fold (0.27 log units), on the high side; measured number inside the range.
By their numbers in this assay, from the lowest: compounds 4, 3 and 2 (each within the scatter of the next, the first and the last beyond it). At a limit, above all of these: compound 1.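

In this assay, this position now gives a step beyond the scatter between two measured numbers, where methyl replaces bromo on an aromatic carbon: a 2.3-fold lower number from compound 2 to compound 4 (0.36 log units; beyond the scatter). Against 4-iodophenyl the change stays inside the scatter, a 1.7-fold lower number from compound 3 to compound 4 (0.24 log units; within the scatter), so that pair has no order. The remaining step, an at least 2.6-fold lower number from compound 1 to compound 4 (0.41 log units; beyond the scatter), is only a floor, as its starting value is a limit: the limit of > 25000 nM in this assay, at which 1 of the 4 values shown sits.

Open, going by these compounds, is whether a 4-methylphenyl group, or a methoxy group or an amine on this phenyl ring, would lower the number further. Also open, on these data alone, is how a shorter chain on the shared core would read.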